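The source may hold more compounds than are shown below. What is called first, only, known or untested is meant among the compounds shown, and "the series" means these compounds.

Measured so far in a functional assay on the whole organism for inhibition, with Rattus norvegicus as the target; a lower number here means that less compound is needed, a higher number that more compound is needed for the effect:
compound 1 `CCOC(=O)c1cnc2n(c1=O)C(C)CC/C2=N\Nc1ccc(C(=O)O)cc1` gives 100 umol/kg
compound 2 `CC1CC/C(=N\Nc2ccc(Cl)cc2)c2ncc(C(=O)O)c(=O)n21` gives 0.5 umol/kg
compound 3 `CCOc1ccc(N/N=C2\CCC(C)n3c2ncc(C(=O)O)c3=O)cc1` gives 1.6 umol/kg

Compound 2 holds the lowest number of the three. Compound 3 stands nearest to it, compound 1 furthest, and both gaps are beyond the scatter. Going by the values given here, only one single-place step is available within this set: a 3.2-fold higher number from compound 2 to compound 3 (0.51 log units; beyond the scatter). Compound 1 differs from compound 2 in more than one place, so for that pair only the two values themselves are noted.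

Compound 4 `Cc1cccc(N/N=C2\CCC(C)n3c2ncc(C(=O)O)c3=O)c1` is the next member to be tested. Relative to compound 2 the change is 3-methylphenyl in place of 4-chlorophenyl on an amine nitrogen.

Among the compounds with values here, no measured pair covers this exact exchange. Within the data shown here, the step from compound 2 to compound 3 is the only guide, and it shows that replacing the group on the amine nitrogen can shift the dose by a modest amount, towards a higher number. Lacking a closer precedent, a step of similar or smaller size in the same direction is expected for compound 4, with wide uncertainty around it. Compound 4 is therefore expected to give 1.5 umol/kg in this assay, within a range of 0.4 umol/kg to 6 umol/kg. This corresponds to an expected step of a 3.0-fold higher number from compound 2 to compound 4 (0.48 log units; beyond the scatter).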

Compound 4, dose for 50% inhibition: 0.4 umol/kg
Estimate against measurement, compound 4: 3.8-fold (0.57 log units) above; low and high end bracket the measured number.
By their numbers in this assay, from the lowest: compounds 4 and 2 (each within the scatter of the next); then compound 3; then compound 1.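

In this assay the exchange of 4-chlorophenyl for 3-methylphenyl on the amine nitrogen gives a 1.3-fold lower number from compound 2 to compound 4 (0.10 log units; within the scatter) and stays inside the usual scatter, so a chlorine on this ring is not required for a number in this range: a ring carrying carbon substituents alone reaches it too. The position does not respond alike to every group, since a 3.2-fold higher number from compound 2 to compound 3 (0.51 log units; beyond the scatter) with ethoxy in place of chloro lies beyond the scatter, a contrast that rests on these three compounds only. Nothing available here bears on why the methyl and chloro compounds stay level while the ethoxy compound does not. The exchange alters the substituent and its numbered place on the ring together, so the compounds shown cannot separate the contribution of each. Also open, on these data alone, is where a plain phenyl, or a ring carrying a nitrile, a trifluoromethyl or an amine, would fall on this scale, and whether any such group on the amine nitrogen would move the number beyond the scatter in either direction.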